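Working notes: sulfonyl-side chain of the shared core

The source may report more compounds than this note shows. Statements on the series, on what has been measured and on what is new or still open speak of the compounds shown alone.

Measured so far in a functional assay, read by fluorescence and spectrophotometry, with a stated time of 1 h; on this read-out lower numbers stand for an effect already at smaller amounts and higher numbers for an effect only at larger amounts of compound:
compound 1 `O=S(=O)(/C=C/c1ccc(O)c(O)c1)CC1CCCCC1` gives 7500 nM
compound 2 `O=S(=O)(/C=C/c1ccc(O)c(O)c1)CCCCCCCCO` gives 6700 nM
compound 3 `CCCCCS(=O)(=O)/C=C/c1ccc(O)c(O)c1` gives 8100 nM

Compound 3 holds the highest of the three numbers, yet the steps of a 1.1-fold higher number from compound 1 to compound 3 (0.03 log units; within the scatter) and a 1.2-fold higher number from compound 2 to compound 3 (0.08 log units; within the scatter) are both within the scatter, so the three compounds cannot be told apart on these numbers. Compound 4 `CCCCCCCS(=O)(=O)/C=C/c1ccc(O)c(O)c1` differs from compound 3 by ethyl in place of hydrogen on a saturated chain carbon, five bonds along the chain from a sulfonyl sulfur. The step of a 1.2-fold higher number from compound 2 to compound 3 (0.08 log units; within the scatter) touches the same saturated chain carbon and stayed within the scatter; the step of a 1.1-fold higher number from compound 1 to compound 3 (0.03 log units; within the scatter), altering the chain bound to the sulfonyl sulfur, did likewise. Among the measured compounds shown here, no step of this kind has moved the read-out beyond the scatter, so for compound 4 the expected step is a 1.1-fold lower number from compound 3 to compound 4 (0.03 log units; within the scatter), nothing beyond the scatter. Compound 4 is therefore estimated at 7500 nM, within 3500 nM to 16000 nM.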

Compound 4, half-maximal effective concentration: 7100 nM
For compound 4 the middle estimate is 1.1-fold (0.02 log units) above the measured one, and the stated range covers the measured number.
By their numbers in this assay, from the lowest: compounds 2, 4, 1 and 3 (each within the scatter of the next).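

Ethyl in place of hydrogen at this chain carbon gives a 1.1-fold lower number from compound 3 to compound 4 (0.06 log units; within the scatter) in this assay and so adds a chain extension at this position to the changes that leave the read-out unresolved. Hydrogen in place of hydroxymethyl, seven bonds along the chain from a sulfonyl sulfur, gives a 1.1-fold higher number from compound 2 to compound 4 (0.03 log units; within the scatter) and hexyl in place of cyclohexyl gives a 1.1-fold lower number from compound 1 to compound 4 (0.02 log units; within the scatter) with the same outcome. No supporting data bear on this result.

As far as these compounds go, whether an amine, a carboxylic acid or a much longer chain on this carbon would move the read-out beyond the scatter remains open.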